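The compounds below may be only part of what the source reports. "The series", "measured", "known", "first", "only" and "open" are said of these compounds alone.

In an ADME assay on NHDF cells (Homo sapiens) for cytotoxicity, read by MTT assay, with a stated time of 72 h (a lower number here means a stronger inhibitor, a higher number a weaker inhibitor), compound 1 (`COc1cccc(/C=C2\CCC/C(=C\c3ccc(Cl)cc3)C2=O)c1OC`) gives 18600 nM while compound 2 (`COc1cccc(/C=C2\CCC/C(=C\c3cccc(Br)c3)C2=O)c1OC`) gives 23900 nM and compound 3 (`COc1cccc(/C=C2\CCC/C(=C\c3cccc(OC)c3OC)C2=O)c1`) gives 16400 nM so that compound 3 sits level with the other two, all three numbers lying within the scatter of one another. Compound 4 (`COc1cccc(/C=C2\CCC/C(=C\c3ccc(O)cc3)C2=O)c1OC`) differs from compound 3 in one place (4-hydroxyphenyl in place of 3-methoxyphenyl on a double-bonded chain carbon bound to a double-bonded ring carbon), on a double-bonded chain carbon bound to a double-bonded ring carbon. For the measured compounds named here, three measured steps bear on this change: (a 1.3-fold higher number from compound 1 to compound 2 (0.11 log units; within the scatter)), (a 1.1-fold lower number from compound 1 to compound 3 (0.05 log units; within the scatter)) and (a 1.5-fold lower number from compound 2 to compound 3 (0.16 log units; within the scatter)), all of them within the scatter. From the compounds shown here alone, none of the three measured compounds carries a 4-hydroxyphenyl, so that group itself remains untested. Starting from compound 3 at 16400 nM no step beyond the scatter is expected in this assay and no direction can be favoured. The estimated step is a 1.0-fold higher number from compound 3 to compound 4 (0.02 log units; within the scatter) and it is expected to stay within the scatter. Compound 4 is estimated at 17000 nM with an expected range from 8000 nM to 36000 nM in this measurement.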

Compound 4, half-maximal inhibitory concentration: > 50000 nM
Compound 4: a limit, no number; the forecaster's own chance of this, stated with the estimate: 8%; middle value at least 2.9-fold (0.46 log units) away from the limit.
By their numbers in this assay, from the lowest: compounds 3, 1 and 2 (each within the scatter of the next). At a limit, above all of these: compound 4.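

In this assay compound 4 gives > 50000 nM, which is a limit of the assay and not a number. The earlier compounds shown here, with 4-chlorophenyl, 3-bromophenyl and 3-methoxyphenyl on the double-bonded chain carbon, lay within the scatter of one another and showed no effect of changing the group at this position. The 4-hydroxyphenyl group is the first shown here to move the number beyond the scatter, with an at least 3.0-fold higher number from compound 3 to compound 4 (0.48 log units; beyond the scatter), an at least 2.0-fold higher number from compound 2 to compound 4 (0.32 log units; beyond the scatter) and an at least 2.6-fold higher number from compound 1 to compound 4 (0.42 log units; beyond the scatter), all in the same direction.

From the compounds shown here alone, the true size of these steps stays open, as each rests on a limit. Going by these compounds, it also remains open whether the shift follows the hydroxy group itself or its place on the ring, a question that a 3-hydroxyphenyl or a 4-methoxyphenyl group would address.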